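Phenoxymethyl replaces 3-fluorophenyl under a cytotoxicity limit

The source may report more compounds than this note shows. Statements on the series, on what has been measured and on what is new or still open speak of the compounds shown alone.

In an ADME assay on HepG2 cells (Homo sapiens) for cytotoxicity, read by MTT assay, with a stated time of 72 h (a lower number here means that less compound is tolerated, a higher number that more compound is tolerated), compound 1 `COc1ccc(C#Cc2cc(Cl)cn3c([N+](=O)[O-])c(CS(=O)(=O)c4ccccc4)nc23)cc1` gives > 3900 nM as a limit of the assay, not a number. Compound 2 `COc1cccc(C#Cc2cc(Cl)cn3c([N+](=O)[O-])c(CS(=O)(=O)c4ccccc4)nc23)c1` gives > 3900 nM as a limit too. Compound 3 `O=[N+]([O-])c1c(CS(=O)(=O)c2ccccc2)nc2c(C#Cc3cccc(F)c3)cc(Cl)cn12` also gives > 3900 nM as a limit, so no number is known for it. All three share one position (the limit of > 3900 nM in this assay, at which 3 of the 3 values shown sit) and cannot be ranked.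

Compound 4 `O=[N+]([O-])c1c(CS(=O)(=O)c2ccccc2)nc2c(C#CCOc3ccccc3)cc(Cl)cn12` differs from compound 3 by phenoxymethyl in place of 3-fluorophenyl on a triple-bonded carbon. Cut one bond further out, the same difference reads 2-(3-fluorophenyl)ethynyl to 3-phenoxyprop-1-yn-1-yl.

Three measured steps alter the group on that triple-bonded carbon: a step that the two limits leave unreadable from compound 1 to compound 2 and a step that the two limits leave unreadable from compound 1 to compound 3 and also a step that the two limits leave unreadable from compound 2 to compound 3 in the same group. None of them has a readable size, so none gives a direction.

What is expected in this assay is therefore no step beyond the scatter, and the estimated step that the limit leaves unreadable from compound 3 to compound 4 favours no firm direction. For the measured compounds named here, compound 4 is expected to return a limit again because the limit of > 3900 nM in this assay, at which 3 of the 3 values shown sit, describes the whole series so far. Compound 4 is estimated at 5000 nM with a range from 2500 nM to 15000 nM as the expected span.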

Compound 4, half-maximal cytotoxic concentration: 8400 nM
Beside the measured number, compound 4's estimate is 1.7-fold (0.23 log units) below it, within the range that was stated.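

Compound 4 gives a number in this assay, but no step from compound 1, compound 2 or compound 3 to it can be read, because each of those three stays at a limit: the limit of > 3900 nM in this assay, at which 3 of the 4 values shown sit.

The compounds shown leave open whether phenoxymethyl, 3-fluorophenyl, 3-methoxyphenyl and 4-methoxyphenyl on the triple-bonded carbon differ at all in this assay, and in which direction.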